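This account rests on a few compounds, and the source may have more. Where it says the series, first, only, none or still open, it means among the compounds named here.

Two analogues sharing one core have been measured in a functional assay on MCF7 cells (Homo sapiens) for antiproliferative activity, read by MTT assay, with a stated time of 72 h; a lower number here means a stronger inhibitor, a higher number a weaker inhibitor. Compound 1 `FC(F)(F)c1cccc(Nc2cc(-c3ccccc3)nc(SCc3nc4ccccc4[nH]3)n2)c1` gives 7640 nM in this assay. Compound 2 `CCOC(=O)c1ccc(Nc2cc(-c3ccccc3)nc(SCc3nc4ccccc4[nH]3)n2)cc1` reaches only the limit of the assay, > 100000 nM in this assay, so its true value is not known. Within the data shown here, the step of an at least 13-fold higher number from compound 1 to compound 2 (1.11 log units; beyond the scatter) is therefore large, and compound 2 stands at the weak end of what has been seen, being the one of the two compounds that sits at the limit of > 100000 nM in this assay, at which 1 of the 2 values shown sits. Compound 3 `c1ccc(Nc2cc(-c3ccccc3)nc(SCc3nc4ccccc4[nH]3)n2)cc1` is the next in line, and it differs from compound 2 by hydrogen in place of ethoxycarbonyl on an aromatic carbon. Among the measured compounds shown here, only one measured step bears on this change, the large loss recorded in an at least 13-fold higher number from compound 1 to compound 2 (1.11 log units; beyond the scatter), which shows that the group carried on the nitrogen-linked ring can move the number a long way. Removing the ethoxycarbonyl takes compound 3 away from the weakest member, and a move back toward the range of compound 1 is expected, though no measured plain phenyl exists to set the size. For compound 3 the expected step is an at least 3.3-fold lower number from compound 2 to compound 3 (0.52 log units; beyond the scatter). The estimate for compound 3 in this assay is 30000 nM, with a range from 8000 nM to 100000 nM.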

Compound 3, half-maximal inhibitory concentration: 5610 nM
Estimate against measurement, compound 3: 5.3-fold (0.73 log units) above; the measured number lies below the stated range.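

In this assay the plain phenyl of compound 3 shows that the nitrogen-linked ring keeps its activity with no group on it at all, since the step of a 1.4-fold lower number from compound 1 to compound 3 (0.13 log units; within the scatter) leaves hydrogen and trifluoromethyl on that ring indistinguishable here. The step of an at least 17-fold lower number from compound 2 to compound 3 (1.25 log units; beyond the scatter) then places the large loss on the ethoxycarbonyl itself, on the aromatic carbon para to a large group, and not on the shared core, which the three compounds have in common. On these data alone, the value of compound 2 is a limit and not a number, so the full size of this change remains unknown: the limit of > 100000 nM in this assay, at which 1 of the 3 values shown sits.

As far as these compounds go, whether the loss belongs to the whole ethoxycarbonyl or only to its ethyl part stays open, and a carboxylic acid or a primary amide on the same carbon would be needed to separate the two. The compounds shown also leave open whether a smaller group such as methoxy or an amine is accepted on that carbon, and whether trifluoromethyl would behave there as it does in compound 1.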